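Shortening a side group on a shared core

The compounds below may be only part of what the source reports. "The series", "measured", "known", "first", "only" and "open" are said of these compounds alone.

Compound 1, `CNC(=O)COc1cc(=O)oc2cc(OCc3cccc(Cl)c3)ccc12`, gives 11% in an assay on isolated protein (strain Sprague-Dawley) for inhibition of Amine oxidase [flavin-containing] A (Rattus norvegicus), read by spectrophotometry, with a stated time of 5 min, tested at 10 uM; a lower number here means less inhibition, a higher number more inhibition at the concentration tested (going by the name of the read-out).
Compound 2, `O=c1cc(CCl)c2ccc(OCc3cccc(Br)c3)cc2o1`, gives 28% in this assay.

Of the two measured compounds, compound 1 gives the lower number, and compound 2 stands higher by a margin beyond the usual scatter. Among the measured compounds shown here, no single-change step links these two, so only their two values can be set side by side. Compound 3, `NC(=O)c1cc(=O)oc2cc(OCc3cccc(Cl)c3)ccc12`, has not yet been measured. It differs from compound 1 in one place: carbamoyl in place of (methylcarbamoyl)methoxy on an aromatic carbon. Nothing measured here shows how such a change acts in this assay, and compound 1 already sits low. The expected step is small, within the scatter, and slightly upward, estimated as a number 4 percentage points higher from compound 1 to compound 3 (within the scatter). Compound 3 is therefore expected to give about 15%, with a range from 0% to 35%.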

Compound 3, a percentage reported as inhibition, at one concentration (the size of the read-out at that concentration, not a potency): 14%
Estimate against measurement, compound 3: 1 percentage points above; the measured number falls inside the stated range.
By their numbers in this assay, from the lowest: compounds 1 and 3 (each within the scatter of the next); then compound 2.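

Shortening the side group on the shared core, with carbamoyl in place of (methylcarbamoyl)methoxy on the aromatic carbon opposite the ring oxygen, gives a number 3 percentage points higher from compound 1 to compound 3 (within the scatter) in this assay. Between these two groups, then, the size of the side group at this position, 6 heavy atoms against 3, does not move the number beyond the usual scatter, and both compounds stay low at the concentration tested. No measurement here offers an explanation for this result.

From the compounds shown here alone, two groups that both contain an amide say little about how this position responds to different kinds of group, so it remains open whether a carboxylic acid, an amine or a plain alkyl chain on the same carbon would change the inhibition. A reading at one concentration also leaves the potency of these compounds open.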